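Notes on replacing the side group of compound 3

The source may report more compounds than this note shows. Statements on the series, on what has been measured and on what is new or still open speak of the compounds shown alone.

Compound 1 `CC(C)CCn1nc(-c2ccn(C)c2)c(O)c(C2=NS(=O)(=O)c3cc(NS(C)(=O)=O)ccc3N2)c1=O` gives > 1000 nM as a limit
Compound 2 `CC(C)CCn1nc(-c2ccccc2)c(O)c(C2=NS(=O)(=O)c3cc(NS(C)(=O)=O)ccc3N2)c1=O` gives > 1000 nM as a limit
Compound 3 `CC(C)CCn1nc(CC2=CCCC2)c(O)c(C2=NS(=O)(=O)c3cc(NS(C)(=O)=O)ccc3N2)c1=O` gives > 33000 nM as a limit

All three readings in an ADME assay on Huh-7 cells (Homo sapiens) for cytotoxicity, with a stated time of 72 h (on this read-out higher numbers stand for lower toxicity in this test and lower numbers for higher toxicity in this test), are limits, not numbers. Compound 3 stands at the limit of > 33000 nM in this assay, at which 1 of the 3 values shown sits, and has no number of its own.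

The change to compound 4 `CCC(C)(C)c1nn(CCC(C)C)c(=O)c(C2=NS(=O)(=O)c3cc(NS(C)(=O)=O)ccc3N2)c1O` is 1,1-dimethylpropyl in place of (cyclopent-1-en-1-yl)methyl on an aromatic carbon, which puts 1,1-dimethylpropyl in place of (cyclopent-1-en-1-yl)methyl on an aromatic carbon.

Among the compounds with values here, the steps that bear on it, all at this same place, are a step that the two limits leave unreadable from compound 1 to compound 3, a step that the two limits leave unreadable from compound 2 to compound 3 and a step that the two limits leave unreadable from compound 1 to compound 2, and the limits leave the size of each unreadable. No measured size can therefore be carried over, and no step beyond the scatter is expected in this assay. The expectation rests on compound 3 alone, whose > 33000 nM is a limit. The estimated step that the limit leaves unreadable from compound 3 to compound 4 is expected to have no clear direction. Compound 4 is estimated at 40000 nM, with an expected range of 12000 nM to 100000 nM, and a report as a limit is likely.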

Compound 4, half-maximal cytotoxic concentration: > 1000 nM
Compound 4: only a limit was reported; the forecaster's own chance of this, stated with the estimate: 75%; the middle value lies beyond the limit too.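

In this assay compound 4 gives > 1000 nM, which is a limit. All four readings are limits, so the steps linking compound 4 to compound 1, compound 2 and compound 3 cannot be read. The compounds shown leave open whether these four side groups differ at all in this assay.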